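A ring swap on compound 3

A few compounds are considered here, and "the series" means these few. Any claim that something is new, unique, unknown or untested is made for them only; others in the source may bear on it.

- compound 1 `Cc1ccsc1/C=C(/SCc1ccc(Cl)cc1Cl)C(=O)c1ccc(Cl)cc1` gives 10000 nM
- compound 2 `Cc1ccc(S/C(=C/c2sccc2C)C(=O)c2ccc(Cl)cc2)cc1` gives 50000 nM
- compound 3 `Cc1ccsc1/C=C(/SCc1ccccc1F)C(=O)c1ccc(Cl)cc1` gives 50000 nM

All three were tested in a functional assay on DU-145 cells (Homo sapiens) for inhibition, read by trypan blue exclusion, with a stated time of 96 h; a lower number here means a stronger inhibitor of growth, a higher number a weaker inhibitor of growth. Compound 3 shares the highest number of this small set with compound 2, and the two cannot be told apart: the record shows no change at the digits printed from compound 2 to compound 3 (within the scatter). Compound 1 is the stronger inhibitor of growth, with a 5.0-fold higher number from compound 1 to compound 3 (0.70 log units; beyond the scatter).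

The next compound is compound 4 `COc1ccccc1/C=C(/SCc1ccccc1F)C(=O)c1ccc(Cl)cc1`, and the change is this: 2-methoxyphenyl in place of 3-methylthiophen-2-yl on a double-bonded chain carbon bound to a double-bonded chain carbon. The new group replaces the 3-methylthiophen-2-yl, which all three measured compounds carry.

Going by the values given here, no measured step touches that place. All of them concern the group on the sulfur: a 5.0-fold higher number from compound 1 to compound 2 (0.70 log units; beyond the scatter) is modest, a 5.0-fold higher number from compound 1 to compound 3 (0.70 log units; beyond the scatter) is the same size, and the third step is flat. They show how far this set moves when another part changes, so they are only a rough guide. From the compounds shown here alone, the direction of the swap is unknown, so the best guess is no step beyond the scatter, leaning slightly lower since compound 3 at 50000 nM shares the top of the set. The expected step is a 1.7-fold lower number from compound 3 to compound 4 (0.22 log units; within the scatter), with real uncertainty either way. For compound 4 the estimated value is 30000 nM, with an expected range of 8000 nM to 100000 nM.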

Compound 4, concentration for 50% growth inhibition: 10000 nM
Estimate against measurement, compound 4: 3.0-fold (0.48 log units) above, within the range that was stated.
By their numbers in this assay, from the lowest: compounds 1 and 4 (each within the scatter of the next); then compounds 2 and 3 (each within the scatter of the next).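

Going by these compounds alone, replacing 3-methylthiophen-2-yl with 2-methoxyphenyl gives a 5.0-fold lower number from compound 3 to compound 4 (0.70 log units; beyond the scatter) in this assay, so the group on the double-bonded chain carbon can also shift growth inhibition, something the earlier steps on the sulfur group could not show. The 2-fluorobenzyl on the sulfur stays the same across this step, while the incoming group differs in several ways at once: a six-membered carbon ring replaces a five-membered ring with one hetero atom, and the heavy-atom count rises from 6 to 8, although both groups have 1 hydrogen-bond acceptor, so this single step cannot assign the effect to any one of these differences. Nothing measured here explains why the number falls with this swap.

A plain phenyl or a 2-hydroxyphenyl at this place would help separate the contribution of the six-membered ring from that of the methoxy group. From the compounds shown here alone, it also remains open whether 2-methoxyphenyl would produce a similar step in a compound carrying 2,4-dichlorobenzyl or 4-methylphenyl on the sulfur.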